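A few compounds are considered here, and "the series" means these few. Any claim that something is new, unique, unknown or untested is made for them only; others in the source may bear on it.

Compound 1, `CC(C)[C@H](NC(=O)CN(c1nc(Cl)nc2[nH]cnc12)C1CC1)C(=O)OCc1ccccc1`, gives 33.4% in a functional assay on the whole organism (Tail, strain ICR) with Mus musculus as the target, in the tail flick test, with a stated time of 30 min, at a dose of 25 umol/kg by the oral route; a higher number here means a stronger effect of the compound at the dose given, a lower number a weaker effect.
Compound 2, `CC[C@H](C)[C@H](NC(=O)CN(c1nc(Cl)nc2[nH]cnc12)C1CC1)C(=O)O`, gives 30.3% in this assay.
Compound 3, `CC[C@H](C)[C@H](NC(=O)CN(c1nc(Cl)nc2[nH]cnc12)C1CC1)C(=O)OCc1ccccc1`, gives 41.4% in this assay.

Compound 2 stands lowest of the three numbers. Its nearest neighbour is compound 1, whose number lies within the scatter of it; its furthest is compound 3, reached by a number 11.1 percentage points higher from compound 2 to compound 3 (beyond the scatter).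

Compound 4, `O=C(O)C[C@H](NC(=O)CN(c1nc(Cl)nc2[nH]cnc12)C1CC1)C(=O)O`, has not been measured in this assay. It differs from compound 2 by carboxymethyl in place of sec-butyl on a saturated chain carbon bound to an amide-type nitrogen and a carbonyl carbon. Within the data shown here, no measured step makes this same change. The step that touches the same part of the molecule is a number 8 percentage points higher from compound 1 to compound 3 (within the scatter), a change on the side chain that stayed within the scatter. The other step, a number 11.1 percentage points higher from compound 2 to compound 3 (beyond the scatter), alters the oxygen next to the carbonyl group and leaves the side chain untouched, so it says nothing about the present change. Among the measured compounds shown here, with only one side-chain step to go on, and that one within the scatter, the step to compound 4 is expected to be small in this assay, with no clear direction and probably not beyond the scatter.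

Compound 4 is therefore estimated at 26% in this assay, within a range of 12% to 40%. This estimate means a step of a number 4.3 percentage points lower from compound 2 to compound 4 (within the scatter), which is expected to stay within the scatter.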

Compound 4, a percentage reported as activity, at one dose (the size of the read-out at that dose, not a potency): 19.9%
Estimate against measurement, compound 4: 6.1 percentage points above; low and high end bracket the measured number.
By their numbers in this assay, from the lowest: compound 4; then compounds 2, 1 and 3 (each within the scatter of the next, the first and the last beyond it).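

In this assay, carboxymethyl in place of sec-butyl on a saturated chain carbon bound to an amide-type nitrogen and a carbonyl carbon gives a number 10.4 percentage points lower from compound 2 to compound 4 (beyond the scatter), so a change at this position can move the number beyond the scatter, if only modestly. The earlier change at the same carbon, methyl in place of hydrogen, gave a number 8 percentage points higher from compound 1 to compound 3 (within the scatter), and it was read with benzyl on the oxygen next to the carbonyl group, whereas the new step is read with that oxygen free of benzyl. No measurement at hand accounts for the lower number with carboxymethyl.

On these data alone, it remains open whether the lower number follows from the carboxylic acid that carboxymethyl brings or from the loss of sec-butyl, a question that an amine, a primary amide or a longer acid chain such as carboxyethyl at the same carbon could help to settle. Also open, as far as these compounds go, is whether the exchange of sec-butyl for carboxymethyl would give a step of similar size with benzyl on the oxygen next to the carbonyl group.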